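Compound 3 and the step to compound 4

The compounds below may be only part of what the source reports. "The series", "measured", "known", "first", "only" and "open" are said of these compounds alone.

Values in a physicochemical assay for solubility (a higher number here means a more soluble compound, a lower number a less soluble compound), so far:
Compound 1 `Cc1nc(-c2cc(C(F)(F)F)ccc2[C@H]2CCOc3cc(S(=O)(=O)Nc4cccc(F)n4)ccc32)co1` gives 13000 nM in this series
Compound 2 `Cc1nc(-c2cc(C(F)(F)F)ccc2[C@H]2CCOc3cc(S(=O)(=O)Nc4ncc(F)cn4)ccc32)co1` gives 281000 nM in this series
Compound 3 `Cc1nc(-c2cc(C(F)(F)F)ccc2[C@H]2CCOc3cc(S(=O)(=O)Nc4nccs4)ccc32)co1` gives 61000 nM in this series

Compound 3 stands second highest of the three, with compound 2 higher and compound 1 lower, and both gaps are beyond the scatter. Compound 4 `O=S(=O)(Nc1nccs1)c1ccc2c(c1)OCC[C@@H]2c1ccc(C(F)(F)F)cc1-c1ccc(F)nc1` keeps the 1,3-thiazol-2-yl on the sulfonamide nitrogen but carries 6-fluoropyridin-3-yl in place of 2-methyl-1,3-oxazol-4-yl on an aromatic carbon. Among the compounds with values here, no measured step touches that place. All three change only the group on the sulfonamide nitrogen, so they bear on it indirectly, as a guide to how far one swap has moved the numbers here. Two are modest (a 4.7-fold higher number from compound 1 to compound 3 (0.67 log units; beyond the scatter) and a 4.6-fold lower number from compound 2 to compound 3 (0.66 log units; beyond the scatter)) and one is large (a 22-fold higher number from compound 1 to compound 2 (1.33 log units; beyond the scatter)). The data give no direct evidence of direction, so the expectation of a modest step to a lower number in this assay is tentative, estimated as a 2.4-fold lower number from compound 3 to compound 4 (0.39 log units; beyond the scatter) with wide uncertainty. Compound 4 is estimated at 25000 nM with an expected range (7000 nM to 80000 nM).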

Compound 4, solubility: 21000 nM
Estimate against measurement, compound 4: 1.2-fold (0.08 log units) above; low and high end bracket the measured number.
By their numbers in this assay, from the lowest: compounds 1 and 4 (each within the scatter of the next); then compound 3; then compound 2.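

The numbers now reach beyond the sulfonamide nitrogen: in this assay, 6-fluoropyridin-3-yl in place of 2-methyl-1,3-oxazol-4-yl, on the aromatic carbon ortho to a large group, gives a 2.9-fold lower number from compound 3 to compound 4 (0.46 log units; beyond the scatter). This position therefore moves the read-out beyond the scatter, and the step is modest, like two of the three swaps on the sulfonamide nitrogen. Nothing measured here accounts for the step.

This single swap changes the ring size, the hetero atoms and the fluorine together, so their separate contributions stay unresolved, as does whether the step would hold with 5-fluoropyrimidin-2-yl on the sulfonamide nitrogen. From the compounds shown here alone, how an amine or a carboxylic acid on this aromatic carbon would read in this assay also remains open.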